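The compounds below may be only part of what the source reports. "The series", "measured", "known", "first", "only" and "open" are said of these compounds alone.

Compound 1 `Nc1ccc2cccc(OC3CCCCCC3)c2n1` gives 137 nM in an assay on cells with melanin-concentrating hormone receptor 1 (Homo sapiens) as the target, read by radioligand binding; a higher number here means a weaker inhibitor, a lower number a stronger inhibitor. Compound 2 `Nc1ccc2cccc(OCC3CCCO3)c2n1` gives > 2000 nM in this assay, a limit rather than a number. Compound 3 `CC(CC(C)(C)C)Oc1cccc2ccc(N3CCCC3)nc12` likewise gives > 2000 nM, again only a limit.

Compound 2 thus stands at the limit of > 2000 nM in this assay, at which 2 of the 3 values shown sit, and no number places it against compound 1. Compound 4 `CSCCOc1cccc2ccc(N)nc12` is not yet measured in this assay. It differs from compound 2 by (methylsulfanyl)methyl in place of oxolan-2-yl on a saturated chain carbon bound to an oxygen on an aromatic ring. Because compound 2 sits at the limit of > 2000 nM in this assay, at which 2 of the 3 values shown sit, any step from it can only be read against that limit, and a step of no more than the scatter is expected, with the estimated step of an at least 1.1-fold lower number from compound 2 to compound 4 (0.04 log units; that floor lies within the scatter). Compound 4 is expected to give about 1800 nM in this assay, within 500 nM to 6000 nM.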

Compound 4, half-maximal inhibitory concentration: > 2000 nM
Compound 4 ended at the assay's limit; the forecaster's own chance of this, stated with the estimate: 45%; middle value at least 1.1-fold (0.04 log units) away from the limit.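

Compound 2 and compound 4 both stand only at a limit in this assay, so no step between them can be read: the limit of > 2000 nM in this assay, at which 3 of the 4 values shown sit.

The compounds shown leave open how far beyond that limit either compound lies, and so whether this change of side chain alters the value at all.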